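Compound 2 to compound 4: expected step

This account rests on a few compounds, and the source may have more. Where it says the series, first, only, none or still open, it means among the compounds named here.

Measured so far in an ADME assay on cells (spleen, Mus musculus, strain C57BL/6) for inhibition, read by flow cytometry and propidium iodide staining, with a stated time of 24 h, at 37 degrees C (on this read-out higher numbers stand for an effect only at larger amounts of compound and lower numbers for an effect already at smaller amounts), for this series:
- compound 1 `CCC(O)Cc1cn(CC(=O)NCc2ccccc2)nn1` at 630 uM
- compound 2 `O=C(Cn1cc(CCCCO)nn1)NCc1ccccc1` at 1700 uM
- compound 3 `O=C(Cn1cc(C(=O)O)nn1)NCc1ccccc1` reported as "non-toxic" (no number reported) without a number

Compound 2 holds the higher of the two numbers, and compound 3 offers no number to compare. Within the data shown here, the next structure is compound 4 `CC(C)(C)OC(=O)NCc1cn(CC(=O)NCc2ccccc2)nn1` with the change (tert-butoxycarbonyl)amino in place of 3-hydroxypropyl on a saturated chain carbon bound to an aromatic carbon as its only difference from compound 2. In short, (tert-butoxycarbonyl)amino replaces 3-hydroxypropyl on a saturated chain carbon bound to an aromatic carbon.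

Among the measured compounds shown here, the only measured step at such a carbon is a 2.7-fold higher number from compound 1 to compound 2 (0.43 log units; beyond the scatter) and it was modest, though beyond the scatter. One step is thin support. A step of similar modest size is expected in this assay and, with compound 2 at 1700 uM as the top number, the expected direction is toward a lower number. The estimated move is a 2.1-fold lower number from compound 2 to compound 4 (0.33 log units; beyond the scatter) as a working figure. For compound 4 the estimate is 800 uM as the expected middle, with an expected range from 250 uM to 2500 uM as its upper end.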

Compound 4, concentration for half-maximal effect: > 2000 uM
Compound 4 was reported as a limit; the forecaster's own chance of this, stated with the estimate: 25%; middle value at least 2.5-fold (0.39 log units) away from the limit.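

In this assay compound 4 is reported only as a limit, > 2000 uM. Against the 3-hydroxypropyl chain the reading is an at least 1.1-fold higher number from compound 2 to compound 4 (0.07 log units; that floor lies within the scatter), so compound 4 cannot be placed in order with compound 2, whereas the reading against the 1-hydroxypropyl chain is an at least 3.1-fold higher number from compound 1 to compound 4 (0.50 log units; beyond the scatter). The earlier numbers covered only hydroxyl-bearing chains on a saturated chain carbon bound to an aromatic carbon; the larger (tert-butoxycarbonyl)amino group now shows that a group without that hydroxyl can stand at this place with no shift towards an effect at smaller amounts.

From the compounds shown here alone, how far compound 4 lies beyond its limit stays open. A free amine in place of (tert-butoxycarbonyl)amino, or a longer plain alkyl chain, would show whether the tert-butoxycarbonyl part or the mere size of the group goes with this reading.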